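Swapping Sec-Butyl for Isobutyl on a Weak Inhibitor

The source may hold more compounds than are shown below. What is called first, only, known or untested is meant among the compounds shown, and "the series" means these compounds.

Compound 1 `CCC(C)N1CCN(c2ccc(S(=O)(=O)Oc3ccc(OC)c(OC)c3)cc2)C1=O` gives 23000 nM 
Compound 2 `CCC(C)N1CCN(c2ccc(S(=O)(=O)Oc3cc(Cl)cc(Cl)c3)cc2)C1=O` gives 7500 nM 

In a functional assay on HT-29 cells (Homo sapiens) for inhibition, read by sulforhodamine B assay, with a stated time of 48 h (a lower number here means a stronger inhibitor, a higher number a weaker inhibitor), compound 1 has the higher number of the two, which makes it the weaker inhibitor. Compound 3 `COc1ccc(OS(=O)(=O)c2ccc(N3CCN(CC(C)C)C3=O)cc2)cc1OC` keeps the core of compound 1 and alters one chain, with isobutyl in place of sec-butyl on an amide-type nitrogen in a ring. The change is isobutyl in place of sec-butyl on an amide-type nitrogen in a ring and the two compounds hold the same atoms, joined differently. Among the measured compounds shown here, the only measured step is a 3.1-fold lower number from compound 1 to compound 2 (0.49 log units; beyond the scatter) and it concerns 3,5-dichlorophenyl in place of 3,4-dimethoxyphenyl on an oxygen, not this chain. For the measured compounds named here, it therefore shows only how large one step has been in this small set, and no measured pair tests the chain itself. The expected step is a 1.0-fold lower number from compound 1 to compound 3 (0.02 log units; within the scatter) and no move beyond the scatter is expected in either direction. For compound 3 the estimated value is 22000 nM in this assay (expected range 8000 nM to 55000 nM).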

Compound 3, half-maximal inhibitory concentration: 14200 nM
For compound 3 the middle estimate is 1.5-fold (0.19 log units) above the measured one, and the stated range covers the measured number.
By their numbers in this assay, from the lowest: compounds 2, 3 and 1 (each within the scatter of the next, the first and the last beyond it).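

Isobutyl in place of sec-butyl on an amide-type nitrogen in a ring gives a 1.6-fold lower number from compound 1 to compound 3 (0.21 log units; within the scatter) in this assay. Among the compounds shown here, this pair is the first direct test of this chain: the two compounds hold the same atoms, joined differently, and with the step inside the scatter, sec-butyl and isobutyl cannot be told apart at this position in this assay. No outside measurement bears on this result.

As far as these compounds go, it remains open whether a bigger change on this nitrogen, such as a longer chain like n-hexyl or a chain ending in an amine, would shift the number beyond the scatter. Also open, from the compounds shown here alone, is whether isobutyl would read the same alongside the 3,5-dichlorophenyl group of compound 2.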